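Replacing fluoro with cyano on compound 3

The source may report more compounds than this note shows. Statements on the series, on what has been measured and on what is new or still open speak of the compounds shown alone.

compound 1 `COc1cc2nc(SCC(=O)Nc3ccc(C(F)(F)F)cc3)nc(Nc3c(C)cc(/C=C/C#N)cc3C)c2cc1OC` gives > 211000 nM as a limit
compound 2 `COc1cc2nc([S+]([O-])CC(=O)Nc3ccc([N+](=O)[O-])cc3)nc(Nc3c(Cl)cc(/C=C/C#N)cc3Cl)c2cc1OC` gives 92800 nM as a number
compound 3 `COc1cc2nc([S+]([O-])CC(=O)Nc3cccc(F)c3)nc(Nc3c(Cl)cc(/C=C/C#N)cc3Cl)c2cc1OC` gives 9550 nM as a number

Compound 1 has only a limit in an ADME assay on MT4 cells (Homo sapiens) for cytotoxicity, read by MTT assay, with a stated time of 5 days (on this read-out higher numbers stand for lower toxicity in this test and lower numbers for higher toxicity in this test), and no actual number. Of the two actual numbers, compound 3 holds the lower one, so it is the more toxic of that pair in this assay.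

Compound 4 `COc1cc2nc([S+]([O-])CC(=O)Nc3cccc(C#N)c3)nc(Nc3c(Cl)cc(/C=C/C#N)cc3Cl)c2cc1OC` carries cyano in place of fluoro on an aromatic carbon and the rest of compound 3 stays the same. Going by the values given here, one measured step touches this same aromatic group: a 9.7-fold lower number from compound 2 to compound 3 (0.99 log units; beyond the scatter) for 3-fluorophenyl in place of 4-nitrophenyl on an amide-type nitrogen. That step changed the group and its place, whereas the new change keeps the place, so a smaller move is expected. The higher number of compound 2 at 92800 nM gives a slight lean upward. A small step is expected a 1.7-fold higher number from compound 3 to compound 4 (0.22 log units; within the scatter) and it is not expected to stand clearly beyond the scatter. Compound 4 is estimated at 16000 nM with an expected range from 5000 nM to 50000 nM in this assay.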

Compound 4, half-maximal cytotoxic concentration: >= 70300 nM
Compound 4 ended at the assay's limit; the forecaster's own chance of this, stated with the estimate: 5%; middle value at least 4.3-fold (0.64 log units) away from the limit.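

In this assay, changing only fluoro to cyano on the aromatic ring gives an at least 7.3-fold higher number from compound 3 to compound 4 (0.86 log units; beyond the scatter). This shows that the group at this place, meta to a large group, can shift the read-out beyond the scatter by itself, whereas the earlier step on this ring changed both the group and its place. The result for compound 4 is a limit rather than an exact number: the limit of >= 70300 nM in this assay, at which 1 of the 4 values shown sits.

As far as these compounds go, the step from compound 2 to compound 4 therefore cannot be read, and the full size of the step from compound 3 to compound 4 remains unknown. The compounds shown also leave open how an amine or a carboxylic acid at this same place would read, so one swap does not establish a trend across groups.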